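Loss of the 3-methylbut-2-en-1-yl chain from compound 1

This account rests on a few compounds, and the source may have more. Where it says the series, first, only, none or still open, it means among the compounds named here.

In a functional assay on A549 cells (Homo sapiens) for inhibition, read by MTT assay, with a stated time of 72 h (a higher number here means a weaker inhibitor, a lower number a stronger inhibitor), compound 1 `COc1ccccc1/C=C/C(=O)c1c(OC)cc(O)c(CC=C(C)C)c1O` gives 12500 nM. Going by the values given here, its only measured neighbour, compound 2 `COc1cc(O)c(CC=C(C)C)c(O)c1C(=O)/C=C/c1cccc([N+](=O)[O-])c1`, gives 15000 nM. The measured step is a 1.2-fold higher number from compound 1 to compound 2 (0.08 log units; within the scatter), so compound 1 holds no distinct place in this pair.

Compound 3 `COc1ccccc1/C=C/C(=O)c1c(O)cc(O)cc1OC` differs from compound 1 at one place: hydrogen in place of 3-methylbut-2-en-1-yl on an aromatic carbon. The 3-methylbut-2-en-1-yl group leaves an aromatic carbon ortho to two hydroxy groups, and hydrogen enters there.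

Among the compounds with values here, the single measured step, a 1.2-fold higher number from compound 1 to compound 2 (0.08 log units; within the scatter), swaps a different group, the 2-methoxyphenyl, and so bears only indirectly on this change. Within the data shown here, no measured pair removes the chain, which leaves the size of the new step open. Even so, this change takes away a whole chain rather than swapping one aryl group for another, so a moderate move toward a higher number in this assay is expected, with little confidence in its size.

The expected step is a 2.4-fold higher number from compound 1 to compound 3 (0.38 log units; beyond the scatter). For compound 3 the estimated value is 30000 nM, with an expected range of 12000 nM to 75000 nM.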

Compound 3, half-maximal inhibitory concentration: 47700 nM
For compound 3 the middle estimate is 1.6-fold (0.20 log units) below the measured one, within the range that was stated.
By their numbers in this assay, from the lowest: compounds 1 and 2 (each within the scatter of the next); then compound 3.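

In this assay, hydrogen in place of the 3-methylbut-2-en-1-yl chain on this aromatic carbon, ortho to two hydroxy groups, gives a 3.8-fold higher number from compound 1 to compound 3 (0.58 log units; beyond the scatter), the only step in the series shown to lie beyond the scatter. Going by these compounds alone, the aryl change gave a 1.2-fold higher number from compound 1 to compound 2 (0.08 log units; within the scatter), so the chain position is the first place where a single change clearly moves the number, and the presence of the chain goes with the lower number, on the evidence of this one pair. No measurement in hand accounts for the size or direction of this step.

The compounds shown leave open whether a saturated 3-methylbutyl chain, a short ethyl group or a longer geranyl chain on this aromatic carbon would stay near compound 1 or fall nearer compound 3, and so whether chain length or the double bond matters to the number. Also open, on these data alone, is whether hydrogen in place of the chain would give a step of similar size when the 3-nitrophenyl group of compound 2 is present.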